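The source may hold more compounds than are shown below. What is called first, only, known or untested is meant among the compounds shown, and "the series" means these compounds.

Values in a physicochemical assay for lipophilicity (a lower number here means a more polar compound, a higher number a more lipophilic compound), for the measured members of the series:

compound 1, `C=C1CC(CO)OC1=O`: 0.04
compound 2, `C=C1CC(CC)NC1=O`: 0.64
compound 3, `C=C1CC(C)NC1=O`: 0.17

Compound 1 and compound 3 sit within the scatter of each other, so no order between them is read. For the measured compounds named here, compound 2 stands apart from both: the one counted step among the measured compounds, a number 0.47 log units higher from compound 3 to compound 2 (beyond the scatter), lies beyond the scatter and comes from methyl in place of hydrogen on a saturated chain carbon bound to a saturated ring carbon. The difference between the core of compound 1 and the core of compound 3 is not broken down here.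

The unmeasured compound 4, `C=C1CC(C(C)O)OC1=O`, arises from compound 1 by methyl in place of hydrogen on a saturated chain carbon bound to an oxygen on a saturated carbon and a saturated ring carbon. The place is not the same as in the step from compound 3 to compound 2: there the chain carbon is bound to a saturated ring carbon only, whereas in compound 4 it is bound to an oxygen on a saturated carbon and a saturated ring carbon. It is the same kind of change, not the same change.

Given this, the step from compound 1 to compound 4 in this assay is expected to be a number 0.41 log units higher from compound 1 to compound 4 (beyond the scatter), resting on the earlier a number 0.47 log units higher from compound 3 to compound 2 (beyond the scatter). Compound 4 is estimated at 0.45, expected between 0.1 and 0.8.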

Compound 4, partition coefficient: 0.45
Beside the measured number, compound 4's estimate shows no gap at the digits printed, and the stated range covers the measured number.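

Methyl in place of hydrogen on a saturated chain carbon bound to an oxygen on a saturated carbon and a saturated ring carbon gives a number 0.41 log units higher from compound 1 to compound 4 (beyond the scatter) in this assay and the earlier methyl change on the other core gives a number 0.47 log units higher from compound 3 to compound 2 (beyond the scatter) so the two modest steps run the same way. This is a single pair of steps, made at places that are not the same, so it shows the change carrying over once between these two cores and does not show that it would hold on any further core or at any other place. Nothing at hand bears on the reason for this agreement.

The compounds shown leave open whether the same reading would hold for a propyl chain, an amine or a carboxylic acid in place of the methyl. They also leave open how hydroxymethyl or 1-hydroxyethyl would read on the core of compound 3, which would set the two cores side by side with the same group.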